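Removing the methyl from the piperazine amide of compound 3

The source may hold more compounds than are shown below. What is called first, only, known or untested is meant among the compounds shown, and "the series" means these compounds.

Measured so far in an assay on isolated protein for inhibition of cathepsin S (Homo sapiens), read by fluorescence, with a stated time of 20 min; on this read-out lower numbers stand for stronger inhibition and higher numbers for weaker inhibition:
compound 1 `N#CC1(NC(=O)[C@@H]2C[C@@H](S(=O)(=O)c3ccccc3)C[C@H]2C(=O)N2CC3CCC(C2)O3)CC1` gives 1 nM
compound 2 `N#CC1(NC(=O)[C@@H]2C[C@@H](S(=O)(=O)c3ccccc3)C[C@H]2C(=O)N2CC3(COC3)C2)CC1` gives 3 nM
compound 3 `CN1CCN(C(=O)[C@@H]2C[C@H](S(=O)(=O)c3ccccc3)C[C@H]2C(=O)NC2(C#N)CC2)CC1` gives 2 nM

Compound 3 holds the second highest of the three numbers in this assay. Its nearest neighbour is compound 2, with a 1.5-fold lower number from compound 2 to compound 3 (0.18 log units; within the scatter) separating them, and its furthest is compound 1, with a 2.0-fold higher number from compound 1 to compound 3 (0.30 log units; within the scatter); both gaps lie within the scatter. For the measured compounds named here, the one step beyond the scatter is a 3.0-fold higher number from compound 1 to compound 2 (0.48 log units; beyond the scatter), a modest change.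

Compound 4 `N#CC1(NC(=O)[C@@H]2C[C@@H](S(=O)(=O)c3ccccc3)C[C@H]2C(=O)N2CCNCC2)CC1` differs from compound 3 by hydrogen in place of methyl on an amine nitrogen in a ring. Going by the values given here, none of the measured steps touches this methyl: all three exchange the whole amide ring on the carbonyl carbon. What they do show is that even swapping the entire ring there moves the number only modestly or not beyond the scatter, as seen from compound 1 through compound 2 to compound 3. A single methyl removed from the ring nitrogen is a smaller change than any of those.

Compound 4 is therefore expected to sit close to compound 3, with a step of a 1.5-fold higher number from compound 3 to compound 4 (0.18 log units; within the scatter) that should fall within the scatter. The estimate for compound 4 in this assay is 3 nM, with a range from 1 nM to 10 nM.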

Compound 4, half-maximal inhibitory concentration: 11 nM
Beside the measured number, compound 4's estimate is 3.7-fold (0.56 log units) below it; measured number above the stated range.
By their numbers in this assay, from the lowest: compounds 1, 3 and 2 (each within the scatter of the next, the first and the last beyond it); then compound 4.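

In this assay, for the compounds shown here, the methyl on the ring nitrogen proves not to be a silent detail: replacing it with hydrogen gives a 5.5-fold higher number from compound 3 to compound 4 (0.74 log units; beyond the scatter) and thus a step beyond the scatter, larger than any step among the earlier compounds, although those exchanged the whole amide ring on the carbonyl carbon. Compound 4 also separates from the other two compounds, with a 3.7-fold higher number from compound 2 to compound 4 (0.56 log units; beyond the scatter) and an 11-fold higher number from compound 1 to compound 4 (1.04 log units; beyond the scatter) both printed as beyond the scatter, the second of them large, so it is the weakest of the four and the piperazin-1-yl amide is the one ring here that falls away from the rest. No measurement shown here offers an explanation for this loss on removing a single carbon from the ring nitrogen.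

The compounds shown carry only hydrogen or methyl on this nitrogen, so they leave open where an ethyl, an acetyl or a longer chain there would fall relative to compound 3. They also leave open whether the step from methyl to hydrogen would be of similar size on a core with a different sulfone substituent in place of the phenyl.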